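Rat Liver Microsome Stability: From Compound 2 to Compound 3

The compounds below may be only part of what the source reports. "The series", "measured", "known", "first", "only" and "open" are said of these compounds alone.

Measured so far in an ADME assay on microsomes from liver (Rattus norvegicus) for metabolic stability, read by LC-MS, with a stated time of 1 h, at 37 degrees C, tested at 4 uM; a higher number here means that more of the compound is left, a lower number that less of the compound is left
Compound 1 `COc1ccc(C(=O)O)cc1-c1cccc(COc2ccc3c(c2)CN(C2CCCC2)C3=O)c1` gives 30%
Compound 2 `O=C(O)c1ccc(Cl)c(-c2cccc(COc3ccc4c(c3)CN(C3CCCC3)C4=O)c2)c1` gives 15%

Compound 2 at 15% stands lowest of the two measured compounds. Compound 3 `COc1ccc(-c2cccc(COc3ccc4c(c3)CN(C3CCCC3)C4=O)c2)cc1C(=O)O` differs from it by one change (3-carboxy-4-methoxyphenyl in place of 5-carboxy-2-chlorophenyl on an aromatic carbon), in which 3-carboxy-4-methoxyphenyl stands in place of 5-carboxy-2-chlorophenyl on an aromatic carbon, meta to a large group. Among the compounds with values here, one measured step bears on this (a number 15 percentage points lower from compound 1 to compound 2 (beyond the scatter)), a modest one with chloro in place of methoxy on an aromatic carbon. Compound 1, which has methoxy, gives 30% in this assay and compound 3 carries methoxy again, so a rise of similar modest size is expected. Within the data shown here, no measured step shows what 3-carboxy in place of 5-carboxy does, so this expectation stays loose. The step is estimated here (a number 12 percentage points higher from compound 2 to compound 3 (beyond the scatter)). For compound 3 the expected value is 27% (estimated range 12% to 48%).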

Compound 3, percent of the compound remaining: 84%
Compound 3: middle estimate off by 57 percentage points, on the low side; measured number above the stated range.
By their numbers in this assay, from the lowest: compound 2; then compound 1; then compound 3.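

In this assay, replacing 5-carboxy-2-chlorophenyl with 3-carboxy-4-methoxyphenyl gives a number 69 percentage points higher from compound 2 to compound 3 (beyond the scatter), a far bigger move than the earlier chloro-for-methoxy swap, which gave a number 15 percentage points lower from compound 1 to compound 2 (beyond the scatter). Changing 5-carboxy-2-methoxyphenyl to 3-carboxy-4-methoxyphenyl keeps the same carboxy and methoxy groups and the shared core, yet gives a number 54 percentage points higher from compound 1 to compound 3 (beyond the scatter), so the arrangement of these two groups on the ring matters much more here than the choice between chloro and methoxy. No measurement available here explains why this arrangement leaves so much more of the compound intact.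

The compounds shown leave open whether the high number would hold with chloro in place of methoxy in the 3-carboxy arrangement. They also cannot say what a nitrile or an amide would do in place of the carboxylic acid.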